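An aminophenyl swap in a tight trio

The source may hold more compounds than are shown below. What is called first, only, known or untested is meant among the compounds shown, and "the series" means these compounds.

Compound 1 `COc1ccc(-c2nc3cccc(-c4cc(OC)c(OC)c(OC)c4)c3o2)cc1F`: 1800 nM
Compound 2 `COc1cc(-c2cccc3nc(-c4cccc(F)c4)oc23)cc(OC)c1OC`: 2600 nM
Compound 3 `COc1cc(-c2cccc3nc(-c4cccc(O)c4)oc23)cc(OC)c1OC`: 2000 nM

In a functional assay on A549 cells (Homo sapiens) for antiproliferative activity, read by MTT assay, with a stated time of 48 h (a higher number here means a weaker inhibitor, a lower number a stronger inhibitor), compound 3, at 2000 nM, stands among three numbers that all lie within the scatter of one another. Compound 4 `COc1cc(-c2cccc3nc(-c4ccc(N)cc4)oc23)cc(OC)c1OC` differs from it at one place: 4-aminophenyl in place of 3-hydroxyphenyl on an aromatic carbon, with 4-aminophenyl in place of 3-hydroxyphenyl on an aromatic carbon. Among the measured compounds shown here, no measured compound carries an amino group. The closest evidence comes from changes on this same phenyl group, a 1.3-fold lower number from compound 2 to compound 3 (0.11 log units; within the scatter) and a 1.1-fold higher number from compound 1 to compound 3 (0.05 log units; within the scatter), and both stay within the scatter. The series therefore gives no reason to expect a step beyond the scatter in this assay. The expected step is a 1.3-fold lower number from compound 3 to compound 4 (0.12 log units; within the scatter). Compound 4 is estimated at 1500 nM, within an expected range of 500 nM to 4500 nM.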

Compound 4, half-maximal inhibitory concentration: 720 nM
The estimate for compound 4 lay 2.1-fold (0.32 log units) above the measured number; measured number inside the range.
By their numbers in this assay, from the lowest: compound 4; then compounds 1, 3 and 2 (each within the scatter of the next).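

In this assay, the earlier changes at this position on the shared core gave no step beyond the scatter, but 4-aminophenyl gives a 2.8-fold lower number from compound 3 to compound 4 (0.44 log units; beyond the scatter) and a 3.6-fold lower number from compound 2 to compound 4 (0.56 log units; beyond the scatter) and a 2.5-fold lower number from compound 1 to compound 4 (0.40 log units; beyond the scatter) in a modest shift. The number at this position can therefore move beyond the scatter with the group placed there. No evidence here explains the shift.

Compound 4 changes both the group and where it sits on the phenyl ring. As far as these compounds go, whether either change alone gives this step remains open, and 3-aminophenyl or 4-hydroxyphenyl at this position would separate the two.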